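The source may hold more compounds than are shown below. What is called first, only, known or untested is meant among the compounds shown, and "the series" means these compounds.

Among the measured compounds shown here, only two compounds have numbers so far: compound 1 (`C=C1[C@H](OC(C)=O)CC(=O)C(C)(C)/C=C/[C@@H](C)C(=O)[C@@]2(OC(C)=O)C[C@@](C)(OC(C)=O)[C@H](OC(C)=O)[C@@H]2[C@H]1OC(C)=O`) and compound 2 (`C=C1[C@H](OCC(C)C)[C@@H](OC(C)=O)[C@@H](OC(C)=O)C(C)(C)[C@@H]2O[C@](O)([C@H](C)[C@@H]2OC(C)=O)[C@@]2(OC(C)=O)C[C@@](C)(OC(C)=O)[C@H](OC(C)=O)[C@@H]2[C@H]1OC(C)=O`). In a functional assay on HeLa cells (Homo sapiens) for inhibition, read by MTT assay, with a stated time of 72 h, tested at 30 ug/mL (a lower number here means less inhibition of growth, a higher number more inhibition of growth at the concentration tested), compound 1 gives 36.3% and stands highest of the two, while compound 2 gives 17.8% and lies lower by a margin beyond the usual scatter. Compound 3 (`C=C1[C@H](OC(C)=O)CC(=O)C(C)(C)/C=C/[C@@H](C)C(=O)[C@@]2(OC(C)=O)C[C@@](C)(OC(=O)c3ccccc3)[C@H](OC(C)=O)[C@@H]2[C@H]1OC(C)=O`) keeps the core of compound 1 and alters a single ester, turning an acetoxy into a benzoyloxy. That change, (phenyl in place of methyl on a carbonyl carbon), places phenyl in place of methyl on a carbonyl carbon. For the measured compounds named here, no measured pair shows what this exchange does, so the expectation can only be a cautious one. It takes compound 1 at 36.3% as its starting point. A small rise in this assay is expected, and it may well stay within the scatter. The expected step of a number 3.7 percentage points higher from compound 1 to compound 3 (within the scatter) is an estimate with little direct evidence behind it. For compound 3 the estimated value is 40% within an expected range of 24% to 56% once it is measured.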

Compound 3, percent growth inhibition at one concentration: 23.8%
Compound 3: middle estimate off by 16.2 percentage points, on the high side, outside the stated range (below it).
By their numbers in this assay, from the lowest: compounds 2 and 3 (each within the scatter of the next); then compound 1.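

In this assay, among the compounds shown here, the exchange of acetoxy to benzoyloxy gives the first readable step for this position, and the number moves down: the step is a number 12.5 percentage points lower from compound 1 to compound 3 (beyond the scatter) at the concentration tested. The ester at this place is therefore not a silent spot on the shared core, since phenyl in place of methyl on a carbonyl carbon, with the rest of compound 1 unchanged, is enough to reduce growth inhibition by more than the usual scatter of the measurement. Nothing at hand gives a reason for this drop, so it stands as an observation about this one pair and no more.

On these data alone, a single exchange cannot show whether the loss belongs to phenyl itself or would follow from any replacement of the methyl, so it remains open what a longer chain, such as butanoyl in place of acetyl, or an acyl group carrying an amine or a carboxylic acid, would do at this place. As far as these compounds go, it is equally open whether the same exchange at one of the other acetoxy groups of compound 1 would give a step of like direction and size.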